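A few compounds are considered here, and "the series" means these few. Any claim that something is new, unique, unknown or untested is made for them only; others in the source may bear on it.

Compound 1 `Fc1ccc(-c2c[nH]c(CNc3ccnc4cc(Cl)ccc34)n2)cc1` and compound 3 `Fc1ccc(-c2nc(CNc3ccnc4cc(Cl)ccc34)[nH]c2CN2CCCC2)cc1` share one core; compound 3 carries (pyrrolidin-1-yl)methyl in place of hydrogen on an aromatic carbon. In a physicochemical assay for lipophilicity, measured as octanol-water partition, at pH 7.4 (on this read-out lower numbers stand for lower lipophilicity and higher numbers for higher lipophilicity), compound 1 gives 4.93 and compound 3 gives 4.77, a step of a number 0.16 log units lower from compound 1 to compound 3 (within the scatter). Compound 2 `Clc1ccc2c(NCc3nc(-c4ccccc4)cs3)ccnc2c1` rests on another core; the difference between the two cores is not broken down here. In this assay compound 2 gives 5.15. Compound 4 `Clc1ccc2c(NCc3nc(-c4ccccc4)c(CN4CCCC4)s3)ccnc2c1` carries (pyrrolidin-1-yl)methyl in place of hydrogen on an aromatic carbon. This is the same kind of change as before, though its surroundings differ: in compound 3 the group sits on a five-membered aromatic ring with 2 nitrogen, next to the ring nitrogen and next to the ring atom that bears a 4-fluorophenyl group, whereas in compound 4 it sits on a five-membered aromatic ring with 1 nitrogen and 1 sulfur, next to the ring sulfur and next to the ring atom that bears a phenyl group. The step in this assay is expected to be a number 0.15 log units lower from compound 2 to compound 4 (within the scatter), beside the earlier one, because the earlier step gave a number 0.16 log units lower from compound 1 to compound 3 (within the scatter). Compound 4 is thus expected at 5, between 4.6 and 5.4.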

Compound 4, distribution coefficient: 6.01
Compound 4: middle estimate off by 1.01 log units, on the low side; measured number outside the range, above it.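

The same change, (pyrrolidin-1-yl)methyl in place of hydrogen on an aromatic carbon, gives in this assay a number 0.86 log units higher from compound 2 to compound 4 (beyond the scatter), against a number 0.16 log units lower from compound 1 to compound 3 (within the scatter), so the step read on the core of compound 1 does not carry over to the core of compound 2. With one pair on each core, this does not show which difference between the two cores goes with the gap, or whether the gap would recur with another group. Nothing measured here accounts for the gap.

Open, on these data alone, is whether morpholin-4-ylmethyl, a carboxylic acid or a longer amine chain on the same aromatic carbon would also give steps that differ between the two cores. Also open, as far as these compounds go, is how much of the gap follows the phenyl group of compound 2 and compound 4 rather than the 4-fluorophenyl group of compound 1 and compound 3.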